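Dichlorophenyl replacing methoxyphenyl in the thioether series

The source may hold more compounds than are shown below. What is called first, only, known or untested is meant among the compounds shown, and "the series" means these compounds.

Three compounds with a shared core are measured in an ADME assay on isolated protein for inhibition of Amine oxidase [flavin-containing] B (Homo sapiens); a lower number here means a stronger inhibitor, a higher number a weaker inhibitor. Compound 1 `C#CCNC1CCc2c(SCCc3ccc(Br)cc3)cccc21` gives 1250 nM. Compound 2 `C#CCNC1CCc2c(SCCc3cccc(Br)c3)cccc21` gives 620 nM. Compound 3 `C#CCNC1CCc2c(SCCc3cccc(OC)c3)cccc21` gives 3820 nM, the highest of the three numbers; its steps to both other compounds lie beyond the scatter. Between compound 1 and compound 2 the step is a 2.0-fold lower number from compound 1 to compound 2 (0.30 log units; within the scatter), within the scatter. From compound 1 to compound 3 the step is a 3.1-fold higher number from compound 1 to compound 3 (0.49 log units; beyond the scatter); from compound 2 to compound 3 it is a 6.2-fold higher number from compound 2 to compound 3 (0.79 log units; beyond the scatter).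

Compound 4 `C#CCNC1CCc2c(SCCc3ccc(Cl)c(Cl)c3)cccc21` is not yet measured. The change from compound 3 is 3,4-dichlorophenyl in place of 3-methoxyphenyl on a saturated chain carbon, two bonds along the chain from a sulfur. The entering group has no hydrogen-bond acceptor, as with the bromophenyls of compounds 1 and 2, where the methoxyphenyl of compound 3 has one.

Among the compounds with values here, the steps that bear on this change are those where the methoxyphenyl is exchanged for a bromophenyl: a drop in the number in this assay in both cases, modest in size. A step of comparable direction is therefore expected here, with a lower number for compound 4 than for compound 3, as a 6.9-fold lower number from compound 3 to compound 4 (0.84 log units; beyond the scatter). Compound 4 is estimated at 550 nM, with a range from 200 nM to 1600 nM.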

Compound 4, half-maximal inhibitory concentration: 2820 nM
Compound 4: middle estimate off by 5.1-fold (0.71 log units), on the low side; measured number outside the range, above it.
By their numbers in this assay, from the lowest: compounds 2 and 1 (each within the scatter of the next); then compounds 4 and 3 (each within the scatter of the next).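

In this assay, removing the hydrogen-bond acceptor of the 3-methoxyphenyl does not by itself separate the two compounds at this position, with a 1.4-fold lower number from compound 3 to compound 4 (0.13 log units; within the scatter) and thus no readable change. The 3,4-dichlorophenyl also parts from both bromophenyls, with a 4.5-fold higher number from compound 2 to compound 4 (0.66 log units; beyond the scatter) and a 2.3-fold higher number from compound 1 to compound 4 (0.35 log units; beyond the scatter) as steps beyond the scatter, so the earlier link between an acceptor-free aryl group and a lower number holds for compounds 1 and 2 while compound 4 goes against it. Within the data shown here, what the earlier compounds could not show is that the aryl groups without an acceptor do not form one level here: the absence of the acceptor does not place a compound with the bromophenyls, and the identity and pattern of the halogen substituents on the ring carry weight at this place on the chain.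

No supporting measurement bears on why the 3,4-dichlorophenyl reads apart from the bromophenyls. From the compounds shown here alone, whether a 3-chlorophenyl would stand with the 3-bromophenyl of compound 2 or with the 3,4-dichlorophenyl of compound 4 remains open, and so does the reading of a longer chain carrying these same aryl groups.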